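Furan-2-yl to 1H-Pyrrol-1-yl: What Binding to Expect

The source may report more compounds than this note shows. Statements on the series, on what has been measured and on what is new or still open speak of the compounds shown alone.

Compound 1 `Cn1c(-c2ccc(Cl)cc2)c(CCC(=O)N2CCC(O)(Cc3ccccc3)CC2)c2cc(Br)ccc21` in an assay on CHO cells for displacement of a labelled ligand from Substance-P receptor (Homo sapiens) (on this read-out higher numbers stand for weaker inhibition and lower numbers for stronger inhibition), gives 0.22 nM.
Compound 2 `CC(=O)c1ccc2c(c1)c(CCC(=O)N1CCC(O)(Cc3ccccc3)CC1)c(-c1ccc(Cl)cc1)n2C` in this assay gives 0.19 nM.
Compound 3 `Cn1c(-c2ccc(Cl)cc2)c(CCC(=O)N2CCC(O)(Cc3ccccc3)CC2)c2cc(-c3ccco3)ccc21` in this assay gives 0.79 nM.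

Compound 3 has the highest number of the three and so is the weakest inhibitor in this set; its steps to both other compounds lie beyond the scatter, as a 3.6-fold higher number from compound 1 to compound 3 (0.56 log units; beyond the scatter) and a 4.2-fold higher number from compound 2 to compound 3 (0.62 log units; beyond the scatter) show. Compound 4 `Cn1c(-c2ccc(Cl)cc2)c(CCC(=O)N2CCC(O)(Cc3ccccc3)CC2)c2cc(-n3cccc3)ccc21` has not been measured. It differs from compound 3 in one place: 1H-pyrrol-1-yl in place of furan-2-yl on an aromatic carbon. Within the data shown here, no measured step exchanges one five-membered aromatic ring for another, so the nearest guidance comes from the two steps into compound 3. Both show that a five-membered aromatic ring at this carbon, replacing a small group, raises the number by a modest amount. Compound 4 keeps a ring of the same size with one hetero atom, so the data give no reason to expect a change of that kind here. The expected step in this assay is a 1.0-fold higher number from compound 3 to compound 4 (0.01 log units; within the scatter), which means no movement beyond the scatter. Compound 4 is therefore estimated at 0.8 nM, with a range from 0.3 nM to 2.5 nM.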

Compound 4, half-maximal inhibitory concentration: 2.3 nM
The estimate for compound 4 lay 2.9-fold (0.46 log units) below the measured number, and the stated range covers the measured number.
By their numbers in this assay, from the lowest: compounds 2 and 1 (each within the scatter of the next); then compound 3; then compound 4.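

In this assay, this position separates two rings that the counts do not: furan-2-yl and 1H-pyrrol-1-yl have the same heavy-atom, hydrogen-bond donor and hydrogen-bond acceptor counts, yet the exchange still gives a step beyond the scatter (a 2.9-fold higher number from compound 3 to compound 4 (0.46 log units; beyond the scatter)). Measured against the non-ring groups, the new ring gives large steps (a 10-fold higher number from compound 1 to compound 4 (1.02 log units; beyond the scatter); a 12-fold higher number from compound 2 to compound 4 (1.08 log units; beyond the scatter)), so the two five-membered aromatic rings on this aromatic carbon are not interchangeable, although bromo and acetyl lie within the scatter of each other. Nothing available explains why the two rings differ.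

The exchange changes two things at once, the hetero atom from oxygen to nitrogen and the ring's point of attachment from a ring carbon to the ring nitrogen, and the compounds shown cannot separate these two changes. Going by these compounds, a ring such as 1H-pyrrol-2-yl, which keeps the attachment through carbon, or thiophen-2-yl, which has sulfur as its hetero atom, would help to tell them apart, while an amine or a carboxylic acid at this carbon remains unexplored in this set.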